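This account rests on a few compounds, and the source may have more. Where it says the series, first, only, none or still open, it means among the compounds named here.

Compound 1 `CCCc1nc(C)c2c(CC)nnc(SC)n12`: in a functional assay for inhibition, with Homo sapiens as the target (on this read-out higher numbers stand for weaker inhibition and lower numbers for stronger inhibition), compound 1 gives > 48000 nM, a limit of the assay rather than a number.
Compound 2 `Cc1nc(C)n2c(=O)n(C)ncc12`: in this assay compound 2 gives > 48000 nM, likewise a limit.

Compound 1 thus stands at the limit, and both known values share it: the limit of > 48000 nM in this assay, at which 2 of the 2 values shown sit. Compound 3 `CCCc1nc(C)c2c(-c3ccccc3)nnc(SC)n12` differs from compound 1 by phenyl in place of ethyl on an aromatic carbon, in words phenyl in place of ethyl on an aromatic carbon. Among the compounds with values here, no measured pair shows this change, and with every known value sitting at the limit, no shift beyond the scatter in either direction is expected. The expected step is a step that the limit leaves unreadable from compound 1 to compound 3. Compound 3 is expected to give about 60000 nM in this assay. For compound 3 the estimate spans 15000 nM to 250000 nM, most likely again reported only as a limit.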

Compound 3, half-maximal inhibitory concentration: > 48000 nM
Compound 3: no number, only a limit (the forecaster's own chance of this, stated with the estimate: 75%); the middle value is on the limit's open side.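

Compound 3 gives only a limit, as compound 1 does, so no step can be read between compound 1 and compound 3: the limit of > 48000 nM in this assay, at which 3 of the 3 values shown sit. The compounds shown leave open whether phenyl and ethyl differ at all in this assay.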